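Aryl Substituent Swap on a Sulfonamide Dopamine Ligand

The source may report more compounds than this note shows. Statements on the series, on what has been measured and on what is new or still open speak of the compounds shown alone.

Measured compounds:
Compound 1: `CCCN(CC[C@H]1CC[C@H](NC(=O)/C=C/c2ccc(F)cc2)CC1)[C@H]1CCc2nc(N)sc2C1` gives 1 nM in an assay on brain for displacement of a labelled ligand from D(3) dopamine receptor (Rattus norvegicus); on this read-out higher numbers stand for weaker inhibition and lower numbers for stronger inhibition.
Compound 2: `CCCN(CC[C@H]1CC[C@H](NS(=O)(=O)c2ccc(OC)cc2)CC1)[C@H]1CCc2nc(N)sc2C1` gives 0.78 nM in this assay.

Compound 2 holds the lowest of the two numbers, but its step from compound 1, a 1.3-fold lower number from compound 1 to compound 2 (0.11 log units; within the scatter), lies within the scatter, so the two compounds cannot be ranked against each other. Compound 3, `CCCN(CC[C@H]1CC[C@H](NS(=O)(=O)c2ccc(C(C)C)cc2)CC1)[C@H]1CCc2nc(N)sc2C1`, differs from compound 2 in one place: isopropyl in place of methoxy on an aromatic carbon, on an aromatic carbon of a six-membered aromatic ring of carbon only, para to a large group.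

For the measured compounds named here, the only measured step, from compound 1 to compound 2, exchanges the whole acyl group for a sulfonyl group and does not touch the substituent on the aromatic ring, so no measured step bears directly on the change to compound 3; it only shows that a considerable change at this end of the molecule left the number within the scatter. Compound 3 is therefore expected to stay close to compound 2, with a step of a 1.9-fold higher number from compound 2 to compound 3 (0.28 log units; within the scatter) and an estimated value of 1.5 nM, ranging from 0.4 nM to 6 nM.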

Compound 3, inhibition constant: 4.5 nM
The estimate for compound 3 lay 3.0-fold (0.48 log units) below the measured number; low and high end bracket the measured number.
By their numbers in this assay, from the lowest: compounds 2 and 1 (each within the scatter of the next); then compound 3.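

In this assay, for the compounds shown here, the exchange of methoxy for isopropyl on the aromatic carbon para to a large group gives a 5.8-fold higher number from compound 2 to compound 3 (0.76 log units; beyond the scatter), the first step in this set that lies beyond the scatter. The position is therefore not indifferent to what it carries: the far larger exchange at the amine nitrogen, a 1.3-fold lower number from compound 1 to compound 2 (0.11 log units; within the scatter), stayed within the scatter, whereas replacing this one substituent, which takes away the single hydrogen-bond acceptor of methoxy and adds one more heavy atom, moves the number measurably. Even so, compound 3 gives 4.5 nM, so the change weakens inhibition only modestly, and nothing in the data shown accounts for the step.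

The two compounds at this position do not tell whether the step comes from losing methoxy or from gaining isopropyl, and a plain hydrogen, a methyl, an ethoxy or a tert-butyl group at the same place would help to separate these two readings. As far as these compounds go, it also remains open whether the same exchange would give a step of similar size with the carbonyl link of compound 1 in place of the sulfonyl link.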